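Moving the Chlorine Around the Benzyl Ring

A few compounds are considered here, and "the series" means these few. Any claim that something is new, unique, unknown or untested is made for them only; others in the source may bear on it.

For the measured compounds named here, compound 2 `Cc1ccc(S(=O)(=O)N(Cc2nnc(Cc3ccccc3Cl)o2)c2cccc(Cl)c2C)cc1` gives 398 nM in a functional assay on CHO cells for antagonist activity at prostaglandin E2 receptor EP1 subtype (Homo sapiens), read by FLIPR and calcium flux (on this read-out lower numbers stand for stronger inhibition and higher numbers for weaker inhibition), the higher of the two numbers measured so far; its nearest neighbour, compound 1 `Cc1ccc(S(=O)(=O)N(Cc2nnc(Cc3ccc(C(F)(F)F)cc3)o2)c2cccc(Cl)c2C)cc1`, gives 158 nM in this assay. Going by the values given here, the only measured step at this position, a 2.5-fold higher number from compound 1 to compound 2 (0.40 log units; beyond the scatter), exchanged the aryl group on the saturated chain carbon bound to an aromatic carbon and was modest in size. Compound 3 `Cc1ccc(S(=O)(=O)N(Cc2nnc(Cc3cccc(Cl)c3)o2)c2cccc(Cl)c2C)cc1` differs from compound 2 by 3-chlorophenyl in place of 2-chlorophenyl on a saturated chain carbon bound to an aromatic carbon. Among the compounds with values here, no measured pair separates a 2-chlorophenyl from a 3-chlorophenyl, so that single modest step is the only guide, and it suggests that rearranging this aryl group shifts the number by a small amount whose direction cannot be read from the data. Compound 3 is therefore expected to give about 250 nM, with a range from 80 nM to 800 nM, which would be an estimated step of a 1.6-fold lower number from compound 2 to compound 3 (0.20 log units; within the scatter), within the scatter.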

Compound 3, inhibition constant: 2000 nM
The estimate for compound 3 lay 8.0-fold (0.90 log units) below the measured number; the measured number lies above the stated range.
By their numbers in this assay, from the lowest: compound 1; then compound 2; then compound 3.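

Moving the chlorine, in the change from 2-chlorophenyl to 3-chlorophenyl, leaves the atom counts untouched, yet in this assay it brings a 5.0-fold higher number from compound 2 to compound 3 (0.70 log units; beyond the scatter) and so shows that the place of this one atom on the ring matters at this position. The earlier pair could not show this, since its two groups differ in both substituent and place. Set against the 4-(trifluoromethyl)phenyl group, the 3-chlorophenyl group gives a 13-fold higher number from compound 1 to compound 3 (1.10 log units; beyond the scatter) and makes compound 3 the weakest of the three, while nothing measured here says what lies behind these differences.

The compounds shown leave open how an unsubstituted phenyl ring, or a methoxy or nitrile group in place of the chlorine, would compare. They also leave open whether a longer chain carrying the aryl group would keep this order.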